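Halogen swap on the arylhydrazide of compound 2

The compounds below may be only part of what the source reports. "The series", "measured", "known", "first", "only" and "open" are said of these compounds alone.

The series shares one core carrying a sulfonylurea and a hydrazide. Compound 1 `NNC(=O)c1c(NC(=O)NS(=O)(=O)c2ccccc2)sc2c1CCCCC2` has a free hydrazide nitrogen. In a functional assay on OVCAR-3 cells (Homo sapiens) for inhibition, with a stated time of 48 h (on this read-out higher numbers stand for weaker inhibition of growth and lower numbers for stronger inhibition of growth), compound 1 gives only a limit of > 100000 nM. Compound 2 `O=C(Nc1sc2c(c1C(=O)NNc1ccc(Cl)cc1)CCCCC2)NS(=O)(=O)c1ccccc1` carries a 4-chlorophenyl on that nitrogen. In this assay compound 2 likewise gives only a limit of > 100000 nM, not a number. The step that the two limits leave unreadable from compound 1 to compound 2 cannot be read because both values sit at the limit of > 100000 nM in this assay, at which 2 of the 2 values shown sit. Compound 3 `O=C(Nc1sc2c(c1C(=O)NNc1ccc(Br)cc1)CCCCC2)NS(=O)(=O)c1ccccc1` differs from compound 2 by bromo in place of chloro on an aromatic carbon. For the measured compounds named here, no measured step bears on this change: the only step recorded, from compound 1 to compound 2, is unreadable, and compound 2 itself has no number to move from. The expected step is a number no higher from compound 2 to compound 3 (the limit leaves the size open), none beyond the scatter, with the limit likely to be reported again. The estimate for compound 3 is 100000 nM, between 30000 nM and 300000 nM.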

Compound 3, concentration for 50% growth inhibition: 14800 nM
Estimate against measurement, compound 3: 6.8-fold (0.83 log units) above, and the stated range ends above it.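

Bromo in place of chloro, on an aromatic carbon para to a large group, is the first change here with a readable effect in this assay, which shows an at least 6.7-fold lower number from compound 2 to compound 3 (0.82 log units; beyond the scatter). Set against the free hydrazide nitrogen, the 4-bromophenyl gives an at least 6.7-fold lower number from compound 1 to compound 3 (0.82 log units; beyond the scatter), so an aryl group on that nitrogen can go with measurable growth inhibition, which the 4-chlorophenyl did not show. Both sizes are only lower bounds, because each step starts from a limit and not from a number: the limit of > 100000 nM in this assay, at which 2 of the 3 values shown sit.

The compounds shown leave open whether the trend follows the halogen, since iodo or fluoro at the same place would be needed to test it, and whether methyl there would do the same. As far as these compounds go, with a single measured number, how far the true gap between the chloro and bromo compounds extends also stays open.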